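This account rests on a few compounds, and the source may have more. Where it says the series, first, only, none or still open, it means among the compounds named here.

Measured so far in an ADME assay on Vero cells (Chlorocebus sabaeus) for cytotoxicity, read by MTT assay, with a stated time of 72 h; a higher number here means that more compound is tolerated, a lower number that less compound is tolerated:
- compound 1 `CCc1nc2ccc(Cl)cn2c1C(=O)NCc1ccc2c(c1)CCN(Cc1ccc(C(F)(F)F)cn1)C2`: > 64 ug/mL, a limit of the assay and not a number
- compound 2 `CCc1nc2ccc(Cl)cn2c1C(=O)NCc1ccc2c(c1)CCN(Cc1ccc(C(F)(F)F)nc1)C2`: 7 ug/mL
- compound 3 `CCc1nc2ccc(Cl)cn2c1C(=O)NCc1ccc2c(c1)CCN(Cc1ccc(Br)cc1)C2`: 30 ug/mL

Compound 3 holds the higher of the two true numbers, and the gap to the other is a 4.3-fold higher number from compound 2 to compound 3 (0.63 log units; beyond the scatter). Compound 1 stands at a limit: the limit of > 64 ug/mL in this assay, at which 1 of the 3 values shown sits.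

The next compound is compound 4 `CCc1nc2ccc(Cl)cn2c1C(=O)NCc1ccc2c(c1)CCN(Cc1ccc(C(C)(C)C)cc1)C2`, with this change from compound 3: tert-butyl in place of bromo on an aromatic carbon. Tert-butyl replaces bromo on an aromatic carbon, para to a large group.

For the measured compounds named here, no measured step makes this exact replacement. The closest evidence comes from exchanges of the whole aromatic group at the same end of the molecule: an at least 9.1-fold lower number from compound 1 to compound 2 (0.96 log units; beyond the scatter) and an at least 2.1-fold lower number from compound 1 to compound 3 (0.32 log units; beyond the scatter), along with the step already given. These show that this assay can respond to changes there, but they do not fix a direction for this one. A small fall is therefore expected, with no clear step beyond the scatter: the estimated step is a 1.5-fold lower number from compound 3 to compound 4 (0.18 log units; within the scatter). For compound 4 the estimated value is 20 ug/mL, with an expected range from 7 ug/mL to 60 ug/mL.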

Compound 4, half-maximal cytotoxic concentration: 37 ug/mL
Compound 4: the middle estimate sits 1.9-fold (0.27 log units) below what was measured; low and high end bracket the measured number.
By their numbers in this assay, from the lowest: compound 2; then compounds 3 and 4 (each within the scatter of the next). At a limit, above all of these: compound 1.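

In this assay, the exchange on the aromatic carbon para to a large group, from bromo with 1 heavy atom to tert-butyl with 4 heavy atoms, gives a 1.2-fold higher number from compound 3 to compound 4 (0.09 log units; within the scatter), so it does not separate the two compounds. The 4-(tert-butyl)phenyl group also stands clear of the 6-(trifluoromethyl)pyridin-3-yl group of compound 2 (a 5.3-fold higher number from compound 2 to compound 4 (0.72 log units; beyond the scatter)), as the 4-bromophenyl group did. Against the 5-(trifluoromethyl)pyridin-2-yl group only a floor can be given (an at least 1.7-fold lower number from compound 1 to compound 4 (0.23 log units; that floor lies within the scatter)), so no gap beyond the scatter is shown. Compound 1 carries a limit and not a number: the limit of > 64 ug/mL in this assay, at which 1 of the 4 values shown sits.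

From the compounds shown here alone, whether this carbon stays as undemanding with an amine or a carboxylic acid in place of tert-butyl remains open. Going by these compounds, it is also open how 4-(trifluoromethyl)phenyl would compare with the two pyridine groups, which would set the trifluoromethyl group on the same phenyl ring as compound 3 and compound 4.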